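This account rests on a few compounds, and the source may have more. Where it says the series, first, only, none or still open, it means among the compounds named here.

Measured so far:
compound 1, `CC(=O)/C(=N\Nc1ccccc1Cl)Nc1cccc(Cl)c1`: 417 nM; 417 nM (2 entries)
compound 2, `CSc1cccc(N/C(=N/Nc2ccccc2Cl)C(C)=O)c1`: > 10000 nM

Compound 1 gives 417 nM; 417 nM (2 entries) in an assay on isolated protein for binding affinity to corticotropin-releasing factor receptor 1 (Homo sapiens); a higher number here means a weaker inhibitor, a lower number a stronger inhibitor. Compound 2 gives > 10000 nM in this assay; this is a limit of the assay, not a number, and a second entry for compound 2 also gives no single number. Of the two values shown, one sits at the limit of > 10000 nM in this assay, at which 1 of the 2 values shown sits, and it is the value of compound 2. For the measured compounds named here, no step between measured compounds that differ in a single place has been recorded, so the size of any change has to be judged without a measured example.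

Compound 3, `CSc1cccc(N/C(=N/Nc2ccccc2C(F)(F)F)C(C)=O)c1`, differs from compound 2 in one place: trifluoromethyl in place of chloro on an aromatic carbon. Compound 2 stands at the limit, and compound 3 is expected to stay close to it, with a step that is estimated to be small and, if anything, toward slightly weaker binding, not clearly beyond the scatter. The estimate for compound 3 is 12000 nM, with a range from 3000 nM to 40000 nM. This estimate means an expected step that the limit leaves unreadable from compound 2 to compound 3.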

Compound 3, inhibition constant: > 10000 nM
Compound 3 ended at the assay's limit (the forecaster's own chance of this, stated with the estimate: 65%); the middle value lies beyond the limit too.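

No size can be read for the change from chloro to trifluoromethyl between compound 2 and compound 3, because both values are limits of the assay and not numbers: the limit of > 10000 nM in this assay, at which 2 of the 3 values shown sit. The compounds shown leave open whether this change alters binding at all in a compound with a readable value, such as compound 1.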